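This account rests on a few compounds, and the source may have more. Where it says the series, first, only, none or still open, it means among the compounds named here.

Compound 1, `CC1(C)CO[C@H]1CN([C@H](CCC(F)(F)F)C(N)=O)S(=O)(=O)c1ccc(Cl)cc1`, in an in vitro ADME assay on microsomes from liver (Homo sapiens) for metabolic stability, read by HPLC (on this read-out lower numbers stand for slow clearance and higher numbers for fast clearance), gives 262 mL/min/kg. Compound 2, `NC(=O)[C@@H](CCC(F)(F)F)N(C[C@@H]1CCCCO1)S(=O)(=O)c1ccc(Cl)cc1`, gives in this assay only a limit of the assay, > 300 mL/min/kg.

Compound 2 therefore has no exact number; it sits at the limit of > 300 mL/min/kg in this assay, at which 1 of the 2 values shown sits. Among the compounds with values here, the single measured step, an at least 1.1-fold higher number from compound 1 to compound 2 (0.05 log units; that floor lies within the scatter), is itself only a floor and stays within the scatter. Compound 3, `NC(=O)[C@@H](CCC(F)(F)F)N(C[C@@H]1COCCO1)S(=O)(=O)c1ccc(Cl)cc1`, differs from compound 2 by 1,4-dioxan-2-yl in place of oxan-2-yl on a saturated chain carbon bound to a sulfonamide nitrogen. Within the data shown here, no measured step covers this exact exchange; the only guide is an at least 1.1-fold higher number from compound 1 to compound 2 (0.05 log units; that floor lies within the scatter), which likewise exchanged the ring on a saturated chain carbon bound to a sulfonamide nitrogen and stayed within the scatter. Compound 3 is therefore expected to give about 350 mL/min/kg, with a range from 170 mL/min/kg to 720 mL/min/kg, most likely again reported as a limit rather than a number. The expected change is a step that the limit leaves unreadable from compound 2 to compound 3, nothing beyond the scatter.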

Compound 3, clearance: 117 mL/min/kg
The estimate for compound 3 lay 3.0-fold (0.48 log units) above the measured number; the whole stated range lies above it.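

On a saturated chain carbon bound to a sulfonamide nitrogen, the choice of ring can clearly move the number in this assay: putting a ring with 2 hetero atoms in place of a ring with 1 gives an at least 2.5-fold lower number from compound 2 to compound 3 (0.40 log units; beyond the scatter). Compound 3 also stands apart from the other ring type shown, with a 2.2-fold lower number from compound 1 to compound 3 (0.35 log units; beyond the scatter), so the earlier step within the scatter did not mean that ring exchanges here make little difference. The first of these steps is only a floor, and its true size cannot be read, as compound 2 has only a limit of the assay: the limit of > 300 mL/min/kg in this assay, at which 1 of the 3 values shown sits.

Whether the second ring oxygen itself accounts for the drop remains open, as a single exchange cannot separate it from the rest of the ring. A morpholine ring, which carries an amine nitrogen, or an open 2-methoxyethyl chain at this place could help test that.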